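Extending the hydroxyalkyl chain from compound 1 to compound 3

The source may hold more compounds than are shown below. What is called first, only, known or untested is meant among the compounds shown, and "the series" means these compounds.

In a functional assay on MOLT-4 cells (Homo sapiens) (a lower number here means a stronger inhibitor, a higher number a weaker inhibitor), compound 1 (`COc1cc(NC(C)CCCNC(=O)NCCO)c2ncccc2c1`) gives > 100000 nM, which is a limit. Compound 2 (`COc1cc(NC(C)CCCNC(=O)NCCCO)c2ncccc2c1`) gives > 100000 nM, also a limit. These two values form (the limit of > 100000 nM in this assay, at which 2 of the 2 values shown sit).

Compound 3 (`COc1cc(NC(C)CCCNC(=O)NCCCCCO)c2ncccc2c1`) carries 3-hydroxypropyl in place of hydroxy on a saturated chain carbon, two bonds along the chain from an amide-type nitrogen.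

Going by the values given here, the only measured step bearing on this is a step that the two limits leave unreadable from compound 1 to compound 2, so it offers no size or direction. Little change in this assay is therefore expected, and a further limit is likely. The expected step is an at least 1.2-fold lower number from compound 1 to compound 3 (0.09 log units; that floor lies within the scatter). For compound 3 the estimate is 80000 nM, with an expected range of 25000 nM to 200000 nM.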

Compound 3, half-maximal inhibitory concentration: 61000 nM
For compound 3 the middle estimate is 1.3-fold (0.12 log units) above the measured one; the measured number falls inside the stated range.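

In this assay, going by these compounds alone, compound 3, with its 5-hydroxypentyl chain, is the first to give a number rather than a limit, 61000 nM. The readable steps are an at least 1.6-fold lower number from compound 1 to compound 3 (0.21 log units; that floor lies within the scatter) and an at least 1.6-fold lower number from compound 2 to compound 3 (0.21 log units; that floor lies within the scatter), so chain length at this position can now be followed in at least one direction. Both steps are floors and not sizes: the limit of > 100000 nM in this assay, at which 2 of the 3 values shown sit.

The compounds shown do not tell whether a longer chain would lower the number further. Nor do they tell whether the terminal hydroxy could give way to an amine or a carboxylic acid.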